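A few compounds are considered here, and "the series" means these few. Any claim that something is new, unique, unknown or untested is made for them only; others in the source may bear on it.

Working notes on the shared core carried by compound 1, `CC(C)[C@H](NC(=O)COc1cccc2ccccc12)C(=O)N[C@@H](CC(=O)O)C(=O)CSc1ncc[nH]1`. In a functional assay on Jurkat cells (Homo sapiens) for inhibition (on this read-out lower numbers stand for stronger inhibition and higher numbers for weaker inhibition), compound 1 gives only a limit of the assay, > 200000 nM, and no number. Compound 2 is `CC(C)[C@H](NC(=O)COc1cccc2ccccc12)C(=O)N[C@@H](CC(=O)O)C(=O)COc1nncc(Cl)c1Cl`. In this assay compound 2 likewise gives only a limit, > 200000 nM. Among the compounds with values here, the one step between measured compounds, a step that the two limits leave unreadable from compound 1 to compound 2, cannot be read in size because of the limit of > 200000 nM in this assay, at which 2 of the 2 values shown sit. Where compound 2 stands on the numbers shown is therefore known only as a limit, with no value beneath it to compare against.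

Compound 3 is `CC(C)[C@H](NC(=O)COc1cccc2ccccc12)C(=O)N[C@@H](CC(=O)O)C(=O)COc1[nH]cnc2nncc1-2`. Relative to compound 2 the change is a group of 9 heavy atoms (5 carbon, 4 nitrogen; one five-membered aromatic ring with 2 hetero atoms, one six-membered aromatic ring with 2 hetero atoms) in place of a group of 8 heavy atoms (4 carbon, 2 nitrogen, 2 chlorine; one six-membered aromatic ring with 2 hetero atoms), on an oxygen on a saturated carbon. The measured step that bears on an exchange at this oxygen on a saturated carbon is of unreadable size, so it gives neither a direction nor a magnitude to carry over. With both measured compounds at the limit, compound 3 is expected to sit at the limit as well, estimated at 200000 nM with a range from 60000 nM to 600000 nM. The expected step in this assay is a number no higher from compound 2 to compound 3 (the limit leaves the size open), none beyond the scatter.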

Compound 3, half-maximal inhibitory concentration: 161000 nM
For compound 3 the middle estimate is 1.2-fold (0.09 log units) above the measured one; the measured number falls inside the stated range.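

In this assay compound 3 is the only one of the three shown to give a number, 161000 nM, rather than a limit, so this position now has one readable value. Exchanging the 4,5-dichloropyridazin-3-yl group on the oxygen on a saturated carbon for the two-ring group gives an at least 1.2-fold lower number from compound 2 to compound 3 (0.09 log units; that floor lies within the scatter), and the wider exchange on the saturated chain carbon bound to a carbonyl carbon gives an at least 1.2-fold lower number from compound 1 to compound 3 (0.09 log units; that floor lies within the scatter). These steps are floors and not sizes, and neither floor goes beyond the scatter, because the other two compounds stand at a limit: the limit of > 200000 nM in this assay, at which 2 of the 3 values shown sit.

Still open, as far as these compounds go, is how far the number can move with a change at this position, since the true size of both steps remains unknown and a single readable value fixes no trend. From the compounds shown here alone, how a plain phenyl group, with no ring nitrogen, or a benzoyl group on the same oxygen would read in this assay also remains open, and so does whether either would give a number clearly beyond the scatter from that of compound 3.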